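From phenyl to cyclopropyl on the amide-type nitrogen

The source may report more compounds than this note shows. Statements on the series, on what has been measured and on what is new or still open speak of the compounds shown alone.

In a functional assay on HCT-116 cells (Homo sapiens) for antiproliferative activity, read by MTT assay, with a stated time of 72 h (on this read-out higher numbers stand for weaker inhibition and lower numbers for stronger inhibition), compound 1 (`COc1ncc(-c2ccc3c(c2)N(c2ccc(F)cc2)C(=O)CO3)cc1NS(=O)(=O)c1ccc(F)cc1`) reads > 40000 nM as a limit of the assay and not a number. Among the compounds with values here, compound 2 (`COc1ncc(-c2ccc3c(c2)N(c2ccccc2)C(=O)CO3)cc1NS(=O)(=O)c1ccc(F)cc1`) gives 18800 nM as the only true number so far. Within the data shown here, compound 3 (`COc1ncc(-c2ccc3c(c2)N(C2CC2)C(=O)CO3)cc1NS(=O)(=O)c1ccc(F)cc1`) has not yet been measured, and it carries cyclopropyl in place of phenyl on an amide-type nitrogen in a ring as its one change. Among the measured compounds shown here, only one measured step bears on this: hydrogen in place of fluoro on an aromatic carbon of that same phenyl gave an at least 2.1-fold lower number from compound 1 to compound 2 (0.32 log units; beyond the scatter) and no more than that is known. That step altered the phenyl, whereas here the whole phenyl leaves, so it points in no firm direction. The expected outcome is a 1.3-fold lower number from compound 2 to compound 3 (0.10 log units; within the scatter) in this assay and so no clear step beyond the scatter. Compound 3 is estimated at 15000 nM with 4000 nM and 40000 nM as the expected ends of its range.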

Compound 3, half-maximal inhibitory concentration: 24300 nM
For compound 3 the middle estimate is 1.6-fold (0.21 log units) below the measured one, and the stated range covers the measured number.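

Cyclopropyl in place of phenyl on the amide-type nitrogen gives a 1.3-fold higher number from compound 2 to compound 3 (0.11 log units; within the scatter) in this assay, so swapping the six-membered aromatic ring for a three-membered non-aromatic ring with fewer heavy atoms produces no clear change at this position. Set against the 4-fluorophenyl group, the same ring gives an at least 1.6-fold lower number from compound 1 to compound 3 (0.21 log units; that floor lies within the scatter), so this comparison does not clearly separate the two compounds. Compound 1 reads as a limit of the assay and not a number, and because of that its comparison yields only a floor: the limit of > 40000 nM in this assay, at which 1 of the 3 values shown sits.

As far as these compounds go, whether any group on this nitrogen can shift the reading well beyond the scatter remains open. How a simple methyl, a longer alkyl chain or a chain ending in an amine would read at this position is unknown from the compounds shown.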